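From chloro to trifluoromethyl: a cytotoxicity step awaiting measurement

The compounds below may be only part of what the source reports. "The series", "measured", "known", "first", "only" and "open" are said of these compounds alone.

Measured so far in an ADME assay on MT4 cells (Homo sapiens) for cytotoxicity, read by MTT assay, with a stated time of 5 days; a lower number here means that less compound is tolerated, a higher number that more compound is tolerated:
- compound 1 `COc1cc2nc(SCC(=O)Nc3ccc(C(F)(F)F)cc3)nc(Nc3c(C)cc(/C=C/C#N)cc3C)c2cc1OC`: > 211000 nM (a limit of the assay)
- compound 2 `COc1cc2nc(SCC(=O)Nc3ccc(Cl)cc3)nc(Nc3c(Cl)cc(/C=C/C#N)cc3Cl)c2cc1OC`: 29500 nM

Within the data shown here, only two compounds have been tested in this assay, and only one of them has given an actual number. Compound 1 reports > 211000 nM, which is a limit and not a number. Compound 2, at 29500 nM, therefore holds the only numerical position on this scale.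

The next compound to be tested is compound 3 `COc1cc2nc(SCC(=O)Nc3ccc(C(F)(F)F)cc3)nc(Nc3c(Cl)cc(/C=C/C#N)cc3Cl)c2cc1OC`. It keeps the rest of compound 2 and has trifluoromethyl in place of chloro on an aromatic carbon, para to a large group: trifluoromethyl in place of chloro on an aromatic carbon. Among the measured compounds shown here, no measured pair of compounds shows what this exchange does in this assay, so the expectation rests on compound 2 and its 29500 nM. A small rise, perhaps not much beyond the usual scatter, is expected, with a 1.4-fold higher number from compound 2 to compound 3 (0.13 log units; within the scatter) as the estimated step. The estimate for compound 3 is 40000 nM, with an expected range of 15000 nM to 130000 nM.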

Compound 3, half-maximal cytotoxic concentration: > 197000 nM
Compound 3 was reported as a limit; the forecaster's own chance of this, stated with the estimate: 15%; at least 4.9-fold (0.69 log units) between middle value and limit.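

Set in this assay, trifluoromethyl in place of chloro on an aromatic carbon, para to a large group, gives an at least 6.6-fold higher number from compound 2 to compound 3 (0.82 log units; beyond the scatter), so this single exchange on the 4-chlorophenyl of compound 2 moves the result by more than the usual scatter. The value of compound 3 is a limit and not a number, so this step gives only a lower bound on the change and not its size: the limit of > 197000 nM in this assay, at which 1 of the 3 values shown sits. Compound 1 also stands at a limit, and the step from it to compound 3, the only other comparison that the new value opens, cannot be read: the limit of > 211000 nM in this assay, at which 1 of the 3 values shown sits.

From the compounds shown here alone, how much compound 3 is actually tolerated remains open, as does whether the group on the nitrogen that separates compound 1 from compound 3 makes any difference once trifluoromethyl is present. Also open, going by these compounds, is how this assay would read with an amine or a carboxylic acid in place of chloro or trifluoromethyl at this position, and whether such groups would fall nearer to compound 2 or to compound 3.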